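A Larger Amide Substituent on the Shared Core

The compounds below may be only part of what the source reports. "The series", "measured", "known", "first", "only" and "open" are said of these compounds alone.

Compound 1, `CCOC(=O)[C@@H]1CCC[C@@H](S(=O)(=O)c2ccc(S(=O)(=O)N(CC)CC)cc2)C1`: 16400 nM
Compound 2, `CCN(CC)C(=O)[C@@H]1CCCN(S(=O)(=O)c2ccc(S(=O)(=O)N(CC)CC)cc2)C1`: 6400 nM

Of the compounds shown here, two have so far been tested in a functional assay on MIA PaCa-2 cells (Homo sapiens) for inhibition, read by MTT assay, with a stated time of 7 days; a lower number here means a stronger inhibitor, a higher number a weaker inhibitor. Compound 1 `CCOC(=O)[C@@H]1CCC[C@@H](S(=O)(=O)c2ccc(S(=O)(=O)N(CC)CC)cc2)C1` gives 16400 nM. Compound 2 `CCN(CC)C(=O)[C@@H]1CCCN(S(=O)(=O)c2ccc(S(=O)(=O)N(CC)CC)cc2)C1` gives 6400 nM, the lower of the two numbers, and the gap between them lies beyond the usual scatter of the measurement. Compound 3 `CCN(CC)S(=O)(=O)c1ccc(S(=O)(=O)N2CCC[C@@H](C(=O)NC3CN(C(=O)OC(C)(C)C)C3)C2)cc1` has not been measured. It differs from compound 2 in a single place: (1-(tert-butoxycarbonyl)azetidin-3-yl)amino in place of diethylamino on a carbonyl carbon. Within the data shown here, no measured pair in this set shows a change of this kind, so the size of the step in this assay is open; a step of moderate size in either direction, or none beyond the scatter, would each be unsurprising. The estimate for compound 3 in this assay is 5000 nM, with a range from 1500 nM to 20000 nM. The expected step is a 1.3-fold lower number from compound 2 to compound 3 (0.11 log units; within the scatter).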

Compound 3, half-maximal inhibitory concentration: 200 nM
For compound 3 the middle estimate is 25-fold (1.40 log units) above the measured one; measured number below the stated range.
By their numbers in this assay, from the lowest: compound 3; then compound 2; then compound 1.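

On the carbonyl carbon of the shared core, replacing diethylamino with (1-(tert-butoxycarbonyl)azetidin-3-yl)amino gives a 32-fold lower number from compound 2 to compound 3 (1.51 log units; beyond the scatter) in this assay and this large step shows that the group on this carbonyl carbon can strongly change the result. Among these compounds, the change also turns a group with no ring and no hydrogen-bond donor into a larger one that has both, and the single step cannot separate these differences. No measurement here explains the gain in strength.

On these data alone, it remains open whether the gain requires the tert-butoxycarbonyl group, the four-membered ring or the amide hydrogen. Compounds with a free azetidin-3-ylamino group or a simple methylamino group on this carbonyl carbon would help to tell these parts apart.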